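Shortening the linker of an ester that shows no activity

A few compounds are considered here, and "the series" means these few. Any claim that something is new, unique, unknown or untested is made for them only; others in the source may bear on it.

Of the compounds shown here, three with a shared core have been tested in a functional assay on K562 cells (Homo sapiens) for inhibition, read by MTT assay, with a stated time of 48 h; a lower number here means a stronger inhibitor, a higher number a weaker inhibitor. Compound 1, `Cc1cc2c(cc1C(=O)c1ccc(C(=O)OCCCCOC(=O)c3ccc(C(=O)Nc4ccc5c(c4)C(C)(C)CCC5(C)C)cc3)cc1)C(C)(C)CCC2(C)C`, gives 84100 nM. For compound 2, `CCCC(CCC)C(=O)OCCCCOC(=O)c1ccc(C(=O)Nc2ccc3c(c2)C(C)(C)CCC3(C)C)cc1`, the assay reports only a limit, > 1000000 nM, and no number. Compound 3, `C=C(c1ccc(C(=O)OCCCCOC(=O)c2ccc(C(=O)Nc3ccc4c(c3)C(C)(C)CCC4(C)C)cc2)cc1)c1cc2c(cc1C)C(C)(C)CCC2(C)C`, also reaches only a limit, > 1000000 nM. Going by the values given here, compound 2 thus sits at the limit of > 1000000 nM in this assay, at which 2 of the 3 values shown sit, the weak end of everything measured here, and no step between two measured compounds that differ in a single place has been recorded.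

Compound 4, `CCCC(CCC)C(=O)OCCOC(=O)c1ccc(C(=O)Nc2ccc3c(c2)C(C)(C)CCC3(C)C)cc1`, differs from compound 2 by ((1-propylbutyl)carbonyl)oxy in place of 2-(((1-propylbutyl)carbonyl)oxy)ethyl on a saturated chain carbon, two bonds along the chain from an oxygen next to a carbonyl group. Among the compounds with values here, with no measured step to lean on, the expectation rests on the value of compound 2 alone: because compound 2 gives > 1000000 nM, the shorter chain in compound 4 is expected to leave it at or near the same limit, with no movement beyond the usual scatter. Compound 4 is therefore estimated at 1500000 nM, within a range from 300000 nM to 5000000 nM. That estimate implies a step that the limit leaves unreadable from compound 2 to compound 4, expected to lie inside the scatter.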

Compound 4, half-maximal inhibitory concentration: 664000 nM
Beside the measured number, compound 4's estimate is 2.3-fold (0.35 log units) above it, and the stated range covers the measured number.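

With the shorter chain, compound 4 gives 664000 nM in this assay, so this ester now has a real number at this position. Compound 2 gives only a limit, > 1000000 nM and not a number. Putting ((1-propylbutyl)carbonyl)oxy in place of 2-(((1-propylbutyl)carbonyl)oxy)ethyl gives an at least 1.5-fold lower number from compound 2 to compound 4 (0.17 log units; that floor lies within the scatter) and the true size of that step cannot be read, because the starting value is only a limit: the limit of > 1000000 nM in this assay, at which 2 of the 4 values shown sit.

The compounds shown leave open whether an amine or a carboxylic acid in place of the ester at this position would move the number beyond the usual scatter. They also leave open whether compound 1, at 84100 nM in this assay and carrying a different ester, would respond to the same shortening.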